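This account rests on a few compounds, and the source may have more. Where it says the series, first, only, none or still open, it means among the compounds named here.

Compound 1 `O=[N+]([O-])c1ccc(CN2CCC(n3cc(CC(OCc4cc(-c5cccc(F)c5)no4)c4ccc(Br)cc4)nn3)CC2)cc1` and compound 2 `COc1cccc(-c2cc(COC(Cc3cn(C4CCN(Cc5ccc([N+](=O)[O-])cc5)CC4)nn3)c3ccc(Br)cc3)on2)c1` share one core and differ in a single aromatic group. In a functional assay on PC-3 cells (Homo sapiens) for cytotoxicity, with a stated time of 48 h (on this read-out higher numbers stand for weaker inhibition and lower numbers for stronger inhibition), compound 1 gives 9000 nM. For compound 2 this assay reports only a limit, > 25000 nM. The measured step of an at least 2.7-fold higher number from compound 1 to compound 2 (0.44 log units; beyond the scatter) is thus known only as a bound, since compound 2 sits at the limit of > 25000 nM in this assay, at which 1 of the 2 values shown sits. Compound 3 `N#Cc1cccc(-c2cc(COC(Cc3cn(C4CCN(Cc5ccc([N+](=O)[O-])cc5)CC4)nn3)c3ccc(Br)cc3)on2)c1` carries a further change at the same aromatic carbon: cyano in place of methoxy on an aromatic carbon. For the measured compounds named here, no measured step follows a change of this kind, and the single measured step concerns a different exchange, so it gives no direction for the move to compound 3. Compound 2 stands at the limit itself, which leaves little ground for a shift either way beyond the scatter. Compound 3 is therefore expected to give about 25000 nM, within a range of 8000 nM to 60000 nM, an expected step of a number no higher from compound 2 to compound 3 (the limit leaves the size open).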

Compound 3, half-maximal inhibitory concentration: > 25000 nM
Compound 3 ended at the assay's limit; the forecaster's own chance of this, stated with the estimate: 60%; the middle value sits exactly at the limit.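

Cyano in place of fluoro at this aromatic carbon gives an at least 2.7-fold higher number from compound 1 to compound 3 (0.44 log units; beyond the scatter) in this assay and so joins methoxy as a second replacement of fluoro that goes with a higher number. The steps between compound 2 and compound 3 cannot be read, so methoxy and cyano cannot be ordered at this position. Of the three compounds, only compound 1 gives a number, and the other two rest on the same assay limit: the limit of > 25000 nM in this assay, at which 2 of the 3 values shown sit.

From the compounds shown here alone, it remains open whether any group on this carbon would give a lower number than compound 1 at 9000 nM in this assay. Going by these compounds, it also remains open how an amine or a carboxylic acid on this carbon would read, and whether the shared limit hides a difference between compound 2 and compound 3.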